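Compound 3 expected to sit near compound 2 in cytotoxicity

This account rests on a few compounds, and the source may have more. Where it says the series, first, only, none or still open, it means among the compounds named here.

Measured so far:
compound 1, `CC1=NN(C(=O)CN2CCCC2)C(c2ccccc2O)C1`, 17900 nM
compound 2, `CC(C)CNCC(=O)N1N=C(c2cc3ccccc3oc2=O)CC1c1ccccc1`, 29700 nM

Of the compounds shown here, two have been tested in a functional assay on MGC-803 cells (Homo sapiens) for cytotoxicity, read by MTT assay, with a stated time of 48 h; on this read-out lower numbers stand for stronger inhibition and higher numbers for weaker inhibition. Compound 1 gives 17900 nM in this assay, and compound 2 gives 29700 nM. Of the two numbers shown, the one for compound 2 is the larger, but the gap to compound 1 falls within the scatter of repeated measurements, so the two compounds cannot be told apart on this read-out.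

Compound 3, `CN1CCN(CC(=O)N2N=C(c3cc4ccccc4oc3=O)CC2c2ccccc2)CC1`, has not yet been measured. It differs from compound 2 in one place: 4-methylpiperazin-1-yl in place of isobutylamino on a saturated chain carbon bound to a carbonyl carbon. Among the compounds with values here, the two measured compounds share neither this chain nor a common core, so no step between measured compounds bears directly on this change.

Within the data shown here, with no comparable step to draw on, the author expects compound 3 to stay close to compound 2 in this assay, with a step of a 1.2-fold lower number from compound 2 to compound 3 (0.07 log units; within the scatter) that does not clearly exceed the scatter. Compound 3 is therefore estimated at 25000 nM, within a range from 8000 nM to 75000 nM.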

Compound 3, half-maximal inhibitory concentration: 46100 nM
The estimate for compound 3 lay 1.8-fold (0.27 log units) below the measured number; low and high end bracket the measured number.
By their numbers in this assay, from the lowest: compounds 1, 2 and 3 (each within the scatter of the next, the first and the last beyond it).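

In this assay, the saturated chain carbon bound to a carbonyl carbon now has its first direct comparison: placing 4-methylpiperazin-1-yl there in place of isobutylamino gives a 1.6-fold higher number from compound 2 to compound 3 (0.19 log units; within the scatter). This exchange is a substantial one on paper, since an open group with no ring and 1 hydrogen-bond donor gives way to a six-membered non-aromatic ring with 2 hetero atoms and 0 hydrogen-bond donors, yet this read-out does not separate compound 2 from compound 3. No other measurement shown bears on this result.

From the compounds shown here alone, it remains open whether a different group at this place, such as a primary amine, a carboxylic acid or a longer alkyl chain, would give a number clearly apart from those of compound 2 and compound 3. Going by these compounds, it also remains open whether the same exchange of isobutylamino for 4-methylpiperazin-1-yl would read alike on another core, such as that of compound 1, or in a test on other cells.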